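Amine side chain variation on the shared core

The compounds below may be only part of what the source reports. "The series", "measured", "known", "first", "only" and "open" are said of these compounds alone.

Compound 1 `Cc1cc(C)c(-n2c(Cl)cn3c(CN(CCC(F)(F)F)CC4CC4)c(C(F)(F)F)nc23)c(C)c1` sits at the high end of the three measured numbers in an assay on cells for displacement of a labelled ligand from corticotropin-releasing factor receptor 1 (Homo sapiens), with a stated time of 100 min; on this read-out lower numbers stand for stronger inhibition and higher numbers for weaker inhibition: compound 1 gives 16 nM. Compound 2 `CCCN(Cc1c(C(F)(F)F)nc2n(-c3c(C)cc(C)cc3C)c(Cl)cn12)CC1CCC1` gives 5.3 nM, and compound 3 `CCN(CCC1CC1)Cc1c(C(F)(F)F)nc2n(-c3c(C)cc(C)cc3C)c(Cl)cn12` gives 13 nM. The measured steps are a 3.0-fold lower number from compound 1 to compound 2 (0.48 log units; beyond the scatter), a 1.2-fold lower number from compound 1 to compound 3 (0.09 log units; within the scatter) and a 2.5-fold higher number from compound 2 to compound 3 (0.39 log units; beyond the scatter); each alters both substituents on the amine nitrogen at once, and none exchanges a small saturated ring for an aromatic one. Compound 4 `Cc1cc(C)c(-n2c(Cl)cn3c(CN(CCC(F)(F)F)Cc4cccc(F)c4)c(C(F)(F)F)nc23)c(C)c1` differs from compound 1 by 3-fluorophenyl in place of cyclopropyl on a saturated chain carbon bound to an amine nitrogen. The measured steps bear on this only loosely, showing that changes at the amine move the numbers modestly in either direction. For compound 4 the step is therefore expected to be small, a 1.3-fold higher number from compound 1 to compound 4 (0.10 log units; within the scatter), and compound 4 is estimated at 20 nM with a range of 6 nM to 70 nM.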

Compound 4, inhibition constant: 49 nM
The estimate for compound 4 lay 2.5-fold (0.39 log units) below the measured number; measured number inside the range.
By their numbers in this assay, from the lowest: compound 2; then compounds 3 and 1 (each within the scatter of the next); then compound 4.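

Within the data shown here, with the 3,3,3-trifluoropropyl arm held constant, this is the first step to change a single amine substituent. In this assay, 3-fluorophenyl in place of cyclopropyl gives a 3.1-fold higher number from compound 1 to compound 4 (0.49 log units; beyond the scatter), so the aromatic ring is accommodated at a modest cost. No measurement available here accounts for this step.

Going by these compounds, it remains open whether the ring or its fluorine drives the change. An unsubstituted benzyl or a pyridylmethyl group on the same amine nitrogen would help separate the two.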